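Removing a Trifluoromethyl Group from Compound 2

A few compounds are considered here, and "the series" means these few. Any claim that something is new, unique, unknown or untested is made for them only; others in the source may bear on it.

compound 1 `O=C1N=C2C=CC=CN2CC1C(O)c1cccs1`: 248000 nM
compound 2 `O=c1nc2ccccn2cc1Cc1ccc(F)cc1C(F)(F)F`: > 1000000 nM (a limit)
compound 3 `CC1(C)OC2O[C@@H](Cc3cn4ccccc4nc3=O)C(OCc3ccccc3)C2O1`: 199000 nM

These three results come from a functional assay on A549 cells (Homo sapiens) for cytotoxicity, read by MTT assay, with a stated time of 24 h; a lower number here means a stronger inhibitor, a higher number a weaker inhibitor. Compound 2 has no numerical value in this series. Its > 1000000 nM is a limit of the assay and not a number. Across the series the record reads (the limit of > 1000000 nM in this assay, at which 1 of the 3 values shown sits), and that one entry belongs to compound 2.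

Compound 4 `O=c1nc2ccccn2cc1Cc1ccc(F)cc1` has not yet been measured. It shares the core of compound 2 and differs from it in one place, with hydrogen in place of trifluoromethyl on an aromatic carbon, ortho to a large group and meta to a fluoro group (hydrogen in place of trifluoromethyl on an aromatic carbon).

Among the compounds with values here, no measured pair shows what such a change does. The expectation therefore rests on compound 1 at 248000 nM and compound 3 at 199000 nM, two values within the scatter of each other. A number somewhat closer to these two is expected, which points toward stronger inhibition, although the assay may again report only a limit. The expected change is an at least 2.2-fold lower number from compound 2 to compound 4 (0.34 log units; beyond the scatter). For compound 4 the estimated value is 450000 nM, with an expected range from 150000 nM to 1000000 nM.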

Compound 4, half-maximal inhibitory concentration: > 1000000 nM
Compound 4: only a limit was reported; the forecaster's own chance of this, stated with the estimate: 30%; middle value at least 2.2-fold (0.34 log units) away from the limit.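

In this assay compound 4 gives > 1000000 nM, which is a limit of the assay and not a number. Compound 2 also has only a limit, so no step can be read between compound 2 and compound 4: the limit of > 1000000 nM in this assay, at which 2 of the 4 values shown sit. The compounds shown leave open whether hydrogen in place of trifluoromethyl changes the number in this assay at all.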